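This account rests on a few compounds, and the source may have more. Where it says the series, first, only, none or still open, it means among the compounds named here.

Measured so far:
- compound 1, `COC(=O)c1cccc(-c2cnc(C(=O)CCCCCCc3ccccc3)o2)c1`: 12 nM
- compound 2, `COc1ccc(-c2cnc(C(=O)CCCCCCc3ccccc3)o2)cc1`: 100 nM
- compound 3, `COc1ncc(-c2cnc(C(=O)CCCCCCc3ccccc3)o2)c(OC)n1`: 26 nM

In an assay (Rattus norvegicus) for inhibition of Fatty-acid amide hydrolase 1 (Homo sapiens) (a higher number here means a weaker inhibitor, a lower number a stronger inhibitor), compound 2 gives the highest of the three numbers; compound 3 sits nearest, with a gap beyond the scatter, and compound 1 sits furthest, also beyond the scatter. Compound 2 is therefore the weakest inhibitor of the three on these numbers.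

Compound 4, `CN1CCN(C(=O)c2cnc(C(=O)CCCCCCc3ccccc3)o2)CC1`, has not yet been measured. It differs from compound 2 in one place: (4-methylpiperazin-1-yl)carbonyl in place of 4-methoxyphenyl on an aromatic carbon. The change sits on an aromatic carbon of a five-membered aromatic ring with 1 nitrogen and 1 oxygen, the same position that carries the aryl group in all three measured compounds.

Within the data shown here, no measured pair shows this kind of change, so the size of the step is not anchored. The three measured compounds all keep a six-membered aromatic ring at this place and differ among themselves beyond the scatter, so the position clearly matters. Compound 4 is expected to land somewhere between compound 2 and compound 1, with the step from compound 2 to compound 4 a 2.0-fold lower number from compound 2 to compound 4 (0.30 log units; within the scatter) estimated as a modest move to a lower number, not far beyond the scatter. For compound 4 the estimate in this assay is 50 nM, with a range of 12 nM to 200 nM.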

Compound 4, inhibition constant: 80 nM
For compound 4 the middle estimate is 1.6-fold (0.20 log units) below the measured one; measured number inside the range.
By their numbers in this assay, from the lowest: compound 1; then compound 3; then compounds 4 and 2 (each within the scatter of the next).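

In this assay, putting (4-methylpiperazin-1-yl)carbonyl in place of 4-methoxyphenyl gives a 1.3-fold lower number from compound 2 to compound 4 (0.10 log units; within the scatter), so the two compounds cannot be told apart. Among these compounds, the position on the five-membered aromatic ring therefore does not require a six-membered aromatic ring, as all the earlier compounds carried: a non-aromatic ring with 2 hetero atoms, joined through a carbonyl, reads the same as the 4-methoxyphenyl group of compound 2. Nothing measured bears on why these two groups read alike.

Still open, going by these compounds, is whether this result depends on the carbonyl or on the ring behind it; a simple dimethylamide or a carboxylic acid at this place would help separate the two. Also open, on these data alone, is how a piperazine with a free ring amine would read here.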